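Dropping the arylazo group: effect on cell toxicity

The compounds below may be only part of what the source reports. "The series", "measured", "known", "first", "only" and "open" are said of these compounds alone.

Compound 2 `Cc1nc(N2Nc3onc(-c4ccccc4)c3C2c2ccc(Cl)cc2)sc1/N=N/c1ccc(Br)cc1` gives 390 nM in an ADME assay on MT4 cells (Homo sapiens) for cytotoxicity, read by MTT assay; on this read-out lower numbers stand for higher toxicity in this test and higher numbers for lower toxicity in this test. Compound 1 `Cc1nc(N2Nc3onc(-c4ccccc4)c3C2c2ccc(Cl)cc2)sc1/N=N/c1ccccc1` gives 260 nM in this assay, and the step of a 1.5-fold higher number from compound 1 to compound 2 (0.18 log units; within the scatter) is within the scatter, so the two stand together. Compound 3 `Cc1csc(N2Nc3onc(-c4ccccc4)c3C2c2ccc(Cl)cc2)n1` differs from compound 2 by a hydrogen atom in place of a group of 9 heavy atoms (6 carbon, 2 nitrogen, 1 bromine; one six-membered aromatic ring of carbon only), on an aromatic carbon. Among the compounds with values here, the one measured step only swaps a bromine inside the group that now leaves, so no measured step bears directly on removing it, and the direction is open. Compound 3 is therefore expected to give roughly 800 nM, a step of a 2.1-fold higher number from compound 2 to compound 3 (0.31 log units; beyond the scatter) that is uncertain, with a range from 200 nM to 4000 nM.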

Compound 3, half-maximal cytotoxic concentration: 230 nM
For compound 3 the middle estimate is 3.5-fold (0.54 log units) above the measured one; low and high end bracket the measured number.
By their numbers in this assay, from the lowest: compounds 3, 1 and 2 (each within the scatter of the next).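

In this assay, removing the whole group at this position, rather than swapping the bromine inside it, leaves the result within the scatter (a 1.7-fold lower number from compound 2 to compound 3 (0.23 log units; within the scatter)) and (a 1.1-fold lower number from compound 1 to compound 3 (0.05 log units; within the scatter)). Compound 1, compound 2 and compound 3 therefore stand together, and with hydrogen on this aromatic carbon the toxicity in this test remains. No evidence on the cause of this is available.

Open, as far as these compounds go, is whether an amine or a carboxylic acid on this aromatic carbon would shift the number. Also open, from the compounds shown here alone, is how much a change to the shared core would matter.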